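This account rests on a few compounds, and the source may have more. Where it says the series, first, only, none or still open, it means among the compounds named here.

Compound 1 `O=C1N=C(N2N=C(c3ccccc3)CC2c2ccccc2O)S/C1=C1/C(=O)Nc2ccccc21` stands with the highest of the two numbers recorded in a functional assay on cells (Cancer cell lines, Homo sapiens) for cytotoxicity, read by sulforhodamine B assay, with a stated time of 48 h (on this read-out lower numbers stand for stronger inhibition of growth and higher numbers for weaker inhibition of growth), giving 4220 nM. For the measured compounds named here, its only measured neighbour, compound 2 `O=C1N=C(N2N=C(c3ccccc3)CC2c2ccccc2O)S/C1=C1/C(=O)Nc2ccc(Br)cc21`, gives 460 nM in this assay, and the step of a 9.2-fold lower number from compound 1 to compound 2 (0.96 log units; beyond the scatter) concerns a different part of the structure. Compound 3 `COc1ccc(C2CC(c3ccccc3)=NN2C2=NC(=O)/C(=C3\C(=O)Nc4ccccc43)S2)cc1` differs from compound 1 by 4-methoxyphenyl in place of 2-hydroxyphenyl on a saturated ring carbon. No measured step touches this part of the shared core, so nothing shown argues for a shift beyond the scatter in either direction. Compound 3 is therefore expected to give about 4000 nM, within 1400 nM to 12000 nM, which means an expected step of a 1.1-fold lower number from compound 1 to compound 3 (0.02 log units; within the scatter).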

Compound 3, concentration for total growth inhibition: 4390 nM
For compound 3 the middle estimate is 1.1-fold (0.04 log units) below the measured one; measured number inside the range.
By their numbers in this assay, from the lowest: compound 2; then compounds 1 and 3 (each within the scatter of the next).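

In this assay putting 4-methoxyphenyl in place of 2-hydroxyphenyl on the saturated ring carbon gives a 1.0-fold higher number from compound 1 to compound 3 (0.02 log units; within the scatter) and so leaves the read-out within the scatter, giving this position its first measured step. Here the loss of the hydrogen-bond donor counted for 2-hydroxyphenyl comes with no step beyond the scatter. Nothing available explains this result.

Two features change together in this step. 2-Methoxyphenyl and 4-hydroxyphenyl would separate them. Going by these compounds, whether an amine or a carboxylic acid at this position would give a step beyond the scatter remains open.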